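The source may report more compounds than this note shows. Statements on the series, on what has been measured and on what is new or still open speak of the compounds shown alone.

The measured compounds:
Compound 1, `O=C(Nc1ccc(OC(F)(F)F)cc1)NC1CCN(C(=O)[C@@H]2CCOC2)CC1`, gives 23 ug/mL in a physicochemical assay for solubility, read by mass spectrometry, in phosphate buffer, with a stated time of 24 h, at pH 7.4; a lower number here means a less soluble compound, a higher number a more soluble compound.
Compound 2, `O=C(Nc1ccc(OC(F)(F)F)cc1)NC1CCN(C(=O)C2CCCOC2)CC1`, gives 94 ug/mL in this assay.
Compound 3, `O=C(Nc1ccc(C(F)(F)F)c(F)c1)NC1CCN(C(=O)C2CCCOC2)CC1`, gives 11 ug/mL in this assay.

Compound 1 and compound 2 share one core, while compound 3 and the unmeasured compound 4, `O=C(Nc1ccc(C(F)(F)F)c(F)c1)NC1CCN(C(=O)[C@@H]2CCOC2)CC1`, share another; the difference between the two cores is not broken down here. Within the first pair, the change oxolan-3-yl in place of oxan-3-yl on a carbonyl carbon made a step of a 4.1-fold lower number from compound 2 to compound 1 (0.61 log units; beyond the scatter). The same change, (oxolan-3-yl in place of oxan-3-yl on a carbonyl carbon), now carries compound 3 to compound 4, and the surroundings of the place are the same word for word, so this is the same change. Compound 3 already gives the lowest number of the three in this assay. The step from compound 3 to compound 4 is expected to be of about the same size as the earlier one, an expectation that rests on a single measured example because of a 4.1-fold lower number from compound 2 to compound 1 (0.61 log units; beyond the scatter), so it is held loosely. Compound 4 is expected to give 2.7 ug/mL in this assay, most likely between 1 ug/mL and 8 ug/mL, an expected step of a 4.1-fold lower number from compound 3 to compound 4 (0.61 log units; beyond the scatter).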

Compound 4, solubility: 1.9 ug/mL
Estimate against measurement, compound 4: 1.4-fold (0.15 log units) above, within the range that was stated.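

In this assay, putting oxolan-3-yl in place of oxan-3-yl on a carbonyl carbon gives a 5.8-fold lower number from compound 3 to compound 4 (0.76 log units; beyond the scatter), while the same change on the other core gave a 4.1-fold lower number from compound 2 to compound 1 (0.61 log units; beyond the scatter), so both steps point the same way and both lie beyond the scatter. For the compounds shown here, this shows that the direction of the change carried over between these two cores, but with only two pairs it does not show that the change would behave this way on every core. No measurement given here explains why the number falls with this change.

The compounds shown leave open whether the other mirror-image form of oxolan-3-yl, which differs at the defined stereocentre, would give a similar step. Also open, going by these compounds, is what would happen on the same carbonyl carbon with a group of another kind, such as an amine or a carboxylic acid, in place of oxan-3-yl or oxolan-3-yl.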